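Aryl swap on the amine nitrogen: compound 2 to compound 3

A few compounds are considered here, and "the series" means these few. Any claim that something is new, unique, unknown or untested is made for them only; others in the source may bear on it.

Compound 2 `S=c1oc(-c2ccc3c(c2)OCCO3)nn1CNc1ccc(Cl)c(Cl)c1` gives 6840 nM in a functional assay, with a stated time of 6 min (on this read-out lower numbers stand for stronger inhibition and higher numbers for weaker inhibition), the highest of the two numbers in hand; compound 1 `Fc1cc(NCn2nc(-c3ccc4c(c3)OCCO4)oc2=S)cc(F)c1F` gives 2920 nM. Within the data shown here, the only measured step, a 2.3-fold higher number from compound 1 to compound 2 (0.37 log units; beyond the scatter), alters the same aryl group and so bears on the present change only loosely. Compound 3 `O=[N+]([O-])c1cccc(NCn2nc(-c3ccc4c(c3)OCCO4)oc2=S)c1` carries 3-nitrophenyl in place of 3,4-dichlorophenyl on an amine nitrogen. Among the measured compounds shown here, no measured step shows how a 3-nitrophenyl fares at this position, so for compound 3 a step in this assay of a 1.2-fold lower number from compound 2 to compound 3 (0.09 log units; within the scatter) is expected, probably within the scatter. The estimate for compound 3 is 5500 nM, with a range of 1800 nM to 17000 nM.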

Compound 3, half-maximal inhibitory concentration: 8870 nM
Compound 3: the middle estimate sits 1.6-fold (0.21 log units) below what was measured, within the range that was stated.
By their numbers in this assay, from the lowest: compound 1; then compounds 2 and 3 (each within the scatter of the next).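

On the amine nitrogen, 3-nitrophenyl and 3,4-dichlorophenyl are not separated in this assay, with a 1.3-fold higher number from compound 2 to compound 3 (0.11 log units; within the scatter); an aryl group carrying neither chlorine nor fluorine therefore stays level with the dichlorinated one. Against 3,4,5-trifluorophenyl the same group gives a 3.0-fold higher number from compound 1 to compound 3 (0.48 log units; beyond the scatter), leaving compound 1 with the lowest number of the three, beyond the scatter from both others. Nothing available accounts for these differences. On these data alone, it remains open how an unsubstituted phenyl, a methoxyphenyl or a cyclohexyl would read on this nitrogen.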